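Cyano for nitro in compound 4: expected growth inhibition

The source may hold more compounds than are shown below. What is called first, only, known or untested is meant among the compounds shown, and "the series" means these compounds.

Three compounds of one series have been run in a functional assay on UO-31 cells (Homo sapiens) for inhibition, read by sulforhodamine B assay, with a stated time of 48 h, tested at 10 uM; a lower number here means less inhibition of growth, a higher number more inhibition of growth at the concentration tested. Compound 1 `CCOC(=O)c1ccc(Nc2ccnc(SCC(=O)c3ccc([N+](=O)[O-])cc3)n2)cc1` gives 41% in this assay. Compound 2 `COc1ccc(C(=O)CSc2nccc(Nc3cccc(C(C)=O)c3)n2)cc1` gives 55%, and compound 3 `CC(=O)c1ccc(Nc2ccnc(SCC(=O)c3ccc(Br)cc3)n2)cc1` gives 38%. Among these three numbers compound 1 stands second highest. Compound 3 lies nearest to it, within the usual scatter, so the two cannot be told apart in this assay. Compound 2 lies furthest from compound 1, beyond the scatter, so compound 2 inhibits growth more than compound 1 at the concentration tested. Among the measured compounds shown here, no two measured compounds differ in only one place, so no single-change step is available within the measured set.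

Compound 4 `CCOC(=O)c1ccc(Nc2ccnc(SCC(=O)c3ccc(C#N)cc3)n2)cc1` is not yet measured. It differs from compound 1 in one place: cyano in place of nitro on an aromatic carbon. For the measured compounds named here, no measured pair shows this change, so its size has no precedent here. The expected step is a number 1 percentage points lower from compound 1 to compound 4 (within the scatter), none beyond the scatter in either direction, and the estimate rests on compound 1 at 41% as the only anchor. Compound 4 is therefore estimated at 40% in this assay, with a range from 26% to 54%.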

Compound 4, percent growth inhibition at one concentration: 52%
Estimate against measurement, compound 4: 12 percentage points below; low and high end bracket the measured number.
By their numbers in this assay, from the lowest: compounds 3 and 1 (each within the scatter of the next); then compounds 4 and 2 (each within the scatter of the next).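

Going from 4-nitrophenyl to 4-cyanophenyl gives, in this assay, a number 11 percentage points higher from compound 1 to compound 4 (beyond the scatter), the first single-change step available in this series. Among the compounds shown here, the position on the aromatic carbon para to a large group is therefore not indifferent to its substituent: with the rest of the structure unchanged, replacing nitro with cyano moves growth inhibition at the concentration tested by more than the usual scatter, which the earlier compounds, none differing in only one place, could not show. No measurement here bears on the reason for this step.

From the compounds shown here alone, the step rests on a single pair carrying the ethyl ester, so it remains open whether the same exchange would give a similar step with a different group on the other side of the shared core. Also open, going by these compounds, is how far this position tolerates other groups, such as an amine, a carboxylic acid or trifluoromethyl, and whether any of them would move growth inhibition beyond that of cyano.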